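The source may hold more compounds than are shown below. What is called first, only, known or untested is meant among the compounds shown, and "the series" means these compounds.

Compounds 1, 2 and 3 share one core and differ only in the aromatic group attached to the aromatic nitrogen of the five-membered ring. Compound 1 is `COc1ccccc1-n1cc(COc2c(/C=C\C(=O)O)ccc(OC)c2CC=C(C)C)nn1`, compound 2 is `COc1cccc(-n2cc(COc3c(/C=C\C(=O)O)ccc(OC)c3CC=C(C)C)nn2)c1` and compound 3 is `COc1ccc(/C=C\C(=O)O)c(OCc2cn(-c3cccc(C#N)c3)nn2)c1CC=C(C)C`. In a functional assay on A549 cells (Homo sapiens) for cytotoxicity, read by MTT assay, with a stated time of 24 h (on this read-out higher numbers stand for weaker inhibition and lower numbers for stronger inhibition), compound 1 gives 43000 nM, and compound 2 gives 42700 nM. Among the measured compounds shown here, the one measured step is a 1.0-fold lower number from compound 1 to compound 2 (0.00 log units; within the scatter), so swapping one methoxyphenyl group for another at that nitrogen kept the read-out within the scatter. Going by these compounds, compound 3 stands apart: in this assay compound 3 has "not determined" (no result reported), so its own number is unknown and only its two relatives give an anchor.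

Compound 4 is `COc1ccc(/C=C\C(=O)O)c(OCc2cn(-c3cccnc3Cl)nn2)c1CC=C(C)C`. It differs from compound 3 in one place: 2-chloropyridin-3-yl in place of 3-cyanophenyl on an aromatic nitrogen. For the measured compounds named here, the only measured step, from compound 1 to compound 2, concerns the same position and lay within the scatter, so an exchange of the aromatic group there has so far produced no step that can be read. Whether the 2-chloropyridin-3-yl group behaves like the methoxyphenyl groups is not known, and the step from compound 3 cannot be sized because compound 3 has no number. Taking compounds 1 and 2 as the anchor, compound 4 is expected to land near their values in this assay, at an estimated 43000 nM with a range from 15000 nM to 120000 nM.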

Compound 4, half-maximal inhibitory concentration: 5600 nM
For compound 4 the middle estimate is 7.7-fold (0.89 log units) above the measured one, outside the stated range (below it).
By their numbers in this assay, from the lowest: compound 4; then compounds 2 and 1 (each within the scatter of the next).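

In this assay, the group on the aromatic nitrogen of the five-membered ring proves able to move the read-out: 2-chloropyridin-3-yl in place of 3-methoxyphenyl gives a 7.6-fold lower number from compound 2 to compound 4 (0.88 log units; beyond the scatter), and in place of 2-methoxyphenyl it gives a 7.7-fold lower number from compound 1 to compound 4 (0.89 log units; beyond the scatter). Among the compounds shown here, the earlier exchange between the two methoxyphenyl groups stayed within the scatter, so these are the first steps at this position that can be read, and both point to stronger inhibition, though only modestly. Nothing measured here accounts for this difference in cytotoxicity.

Going by these compounds, the step from compound 3 to compound 4 cannot be read, so the standing of the 3-cyanophenyl group at this position stays open. The 2-chloropyridin-3-yl group also differs from the methoxyphenyl groups in two ways at once, with a ring nitrogen and a chlorine, and the compounds shown cannot separate them: an unsubstituted pyridin-3-yl group or a 2-chlorophenyl group would be needed to tell which of the two goes with the lower number.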